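From isopropyl to sulfamoyl on a shared core

The source may hold more compounds than are shown below. What is called first, only, known or untested is meant among the compounds shown, and "the series" means these compounds.

Measured in an ADME assay on cells (Fibroblast, Homo sapiens) for inhibition, read by MTT assay, with a stated time of 24 h; a higher number here means a weaker inhibitor, a lower number a stronger inhibitor:
Compound 1 `CCCc1ccc(C(=O)N/N=C/c2ccc3c(c2)no[n+]3[O-])cc1`: > 200000 nM (a limit)
Compound 2 `CC(C)c1ccc(C(=O)N/N=C/c2ccc3c(c2)no[n+]3[O-])cc1`: > 200000 nM (a limit)

In this assay, compound 2 stands at > 200000 nM, which is a limit and not a number. Compound 1 gives > 200000 nM, which is also a limit. The evidence so far is the limit of > 200000 nM in this assay, at which 2 of the 2 values shown sit.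

Compound 3 `NS(=O)(=O)c1ccc(C(=O)N/N=C/c2ccc3c(c2)no[n+]3[O-])cc1` carries sulfamoyl in place of isopropyl on an aromatic carbon. Among the compounds with values here, the only measured step is a step that the two limits leave unreadable from compound 1 to compound 2, and it has no readable size. No change beyond the scatter is therefore expected, and no direction can be foreseen. The expected step is a number no higher from compound 2 to compound 3 (the limit leaves the size open). Compound 3 is estimated at 200000 nM, with an expected range from 80000 nM to 400000 nM.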

Compound 3, half-maximal inhibitory concentration: 60000 nM
Beside the measured number, compound 3's estimate is 3.3-fold (0.52 log units) above it; the whole stated range lies above it.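

In this assay, the position on an aromatic carbon para to a large group proves able to change the result: sulfamoyl in place of isopropyl gives an at least 3.3-fold lower number from compound 2 to compound 3 (0.52 log units; beyond the scatter), and sulfamoyl in place of propyl gives an at least 3.3-fold lower number from compound 1 to compound 3 (0.52 log units; beyond the scatter). Neither step has a known full size, and the step between the two alkyl groups still cannot be read. Compound 3 is the only one with a number rather than a limit: the limit of > 200000 nM in this assay, at which 2 of the 3 values shown sit.

Going by these compounds, the true size of the drop remains open, as compound 1 and compound 2 have only limits. On these data alone, it is also open whether an amine or a carboxylic acid at this position would lower the number too.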